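A few compounds are considered here, and "the series" means these few. Any claim that something is new, unique, unknown or untested is made for them only; others in the source may bear on it.

Measured compounds in an assay for inhibition of kynurenine 3-monooxygenase (Rattus norvegicus), tested at 10 uM; on this read-out lower numbers stand for less inhibition and higher numbers for more inhibition at the one concentration tested (going by the name of the read-out):

- compound 1, `COC(=O)C(=N)/C=C(\O)c1ccc(Cl)c(Cl)c1`, gives 37%
- compound 2, `COC(=O)C(=N)/C=C(\O)c1ccc(F)c(Cl)c1`, gives 4%
- compound 3, `N/C(=C\C(=O)c1ccc(Cl)cc1)C(=O)O`, gives 33%

Compound 1 and compound 2 share a core and differ in one place: fluoro in place of chloro on an aromatic carbon. This change is accompanied by a number 33 percentage points lower from compound 1 to compound 2 (beyond the scatter), a step well beyond the usual scatter of this assay.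

Compound 3 sits on a different core; the difference between the core of compound 3 and the core of compound 1 is not broken down here. Compound 3 and compound 1 give numbers within the scatter of each other, so no order between them is read, while compound 2 lies clearly lower than compound 3.

Compound 4, `N/C(=C\C(=O)c1ccc(F)cc1)C(=O)O`, is not yet measured. It differs from compound 3 in one place: fluoro in place of chloro on an aromatic carbon. Among the compounds with values here, this is the same kind of change as the one from compound 1 to compound 2, but the surroundings differ: in compound 1 the changed position is ortho to a chloro group and para to a group of 9 heavy atoms, whereas in compound 3 it is para to a group of 8 heavy atoms, with no ortho chloro group. Within the data shown here, with only one earlier instance of the change, and that on a different core with a different neighbourhood, the expectation for compound 4 rests chiefly on the drop seen in a number 33 percentage points lower from compound 1 to compound 2 (beyond the scatter), tempered because the starting value of compound 3 in this assay is 33% and the place is not the same. A step of a number 18 percentage points lower from compound 3 to compound 4 (beyond the scatter) is therefore expected for compound 4, smaller than the earlier one. Compound 4 is estimated at 15%, expected to fall between 0% and 35%.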

Compound 4, a percentage reported as inhibition, at one concentration (the size of the read-out at that concentration, not a potency): 41%
The estimate for compound 4 lay 26 percentage points below the measured number, outside the stated range (above it).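

In this assay, fluoro in place of chloro on an aromatic carbon para to a group of 8 heavy atoms gives a number 8 percentage points higher from compound 3 to compound 4 (within the scatter), so no order is read between compound 3 and compound 4. The step seen on the core of compound 1 therefore does not carry over as a fixed increment to the core of compound 3, and a result for this change on one core is a poor guide to its result on the other: the same change on two cores in this assay, a number 33 percentage points lower (beyond the scatter) from compound 1 to compound 2 and a number 8 percentage points higher (within the scatter) from compound 3 to compound 4, 41 percentage points apart, beyond the scatter of two such steps This does not show what sets the two steps apart, since the two pairs differ both in the core and in the surroundings of the changed position, and a single pair on each core cannot separate these or support a general rule for the series.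

The compounds shown leave open how other groups on the same aromatic carbon, such as bromo, methyl, methoxy or nitrile, would read in this assay on either core. They also leave open whether the exchange of chloro for fluoro on a further core would follow the step of compound 1 to compound 2, that of compound 3 to compound 4, or neither.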